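Adding a (Dimethylamino)methyl Group to Compound 3

The source may hold more compounds than are shown below. What is called first, only, known or untested is meant among the compounds shown, and "the series" means these compounds.

Compounds tested so far, with their results in an assay on C6 glioma cells for displacement of a labelled ligand from sodium- and chloride-dependent glycine transporter 1 (Rattus norvegicus), read by scintillation counting, with stated times of 30 min and 10 min; on this read-out lower numbers stand for stronger inhibition and higher numbers for weaker inhibition:
compound 1, `Cc1nnc(-c2ccc(-c3ccncc3)cc2)n1-c1ccccc1F`, gives 5900 nM
compound 2, `CCc1nnc(N2CCC(c3ccccc3)CC2)n1-c1ccccc1F`, gives 3700 nM
compound 3, `CCc1nnc(-c2ccc(-c3ccccc3)cc2)n1-c1ccccc1C`, gives 300 nM

Among these three, compound 3 shows the lowest number in this assay, and the gaps to both compound 2 and compound 1 are beyond the scatter, so compound 3 is the strongest inhibitor of the three. Compound 3 carries a biphenyl group and an ethyl group on the shared core, and a methyl-bearing aromatic ring on its nitrogen.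

Compound 4, `CCc1nnc(-c2ccc(-c3ccccc3)cc2)n1-c1cccc(CN(C)C)c1C`, keeps all of this and differs from compound 3 in a single place: (dimethylamino)methyl in place of hydrogen on an aromatic carbon. For the measured compounds named here, no pair of measured compounds shows the effect of such a change, so there is no step to lean on. The new group is not part of a ring, holds one hydrogen-bond acceptor and carries no net charge.

Without a comparable step, the expectation for compound 4 in this assay is that the change stays close to what compound 3 shows, perhaps drifting toward a slightly higher number. The step from compound 3 to compound 4 is therefore expected to be a 1.5-fold higher number from compound 3 to compound 4 (0.18 log units; within the scatter). Compound 4 is estimated at 450 nM, within a range from 120 nM to 1800 nM.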

Compound 4, half-maximal inhibitory concentration: 29000 nM
Compound 4: middle estimate off by 64-fold (1.81 log units), on the low side; measured number above the stated range.
By their numbers in this assay, from the lowest: compound 3; then compounds 2 and 1 (each within the scatter of the next); then compound 4.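

In this assay, placing (dimethylamino)methyl on this aromatic carbon, ortho to a methyl group and meta to a large group, is far from a neutral change: it gives a 97-fold higher number from compound 3 to compound 4 (1.99 log units; beyond the scatter) and so turns a comparatively strong inhibitor into a much weaker one. For the compounds shown here, this is the first reading at this position, since the earlier compounds carry only hydrogen there, and it shows that adding a single group of 4 heavy atoms with no ring and no net charge can by itself cost a very large part of the inhibition seen with compound 3. Nothing available here bears on why the number rises so steeply.

The compounds shown leave open whether it is the amine nitrogen or simply the presence of a chain at this carbon that matters, a question that a hydroxymethyl group or an ethyl group in the same place could help to answer. They also leave open whether the same (dimethylamino)methyl group would have a similar effect on a different carbon of this ring.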